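Series notes: selenium to oxygen on the aromatic ring

A few compounds are considered here, and "the series" means these few. Any claim that something is new, unique, unknown or untested is made for them only; others in the source may bear on it.

Measured so far:
Compound 1 `COc1ccc(CNc2nc([SeH])nc3ccccc23)cc1` — > 100000 nM
Compound 2 `CSc1nc(NCc2ccc([Se]C)cc2)c2ccccc2n1` — > 100000 nM

In a functional assay on HT-29 cells (Homo sapiens) for cytotoxicity, read by MTT assay, with a stated time of 72 h (on this read-out higher numbers stand for weaker inhibition of growth and lower numbers for stronger inhibition of growth), compound 1 returns only a limit of the assay, > 100000 nM. Compound 2 also returns only a limit in this assay, > 100000 nM. Among the measured compounds shown here, the whole picture so far is the limit of > 100000 nM in this assay, at which 2 of the 2 values shown sit, so compound 2 stands at the weak edge of what has been measured and no step between measured compounds is resolved. Compound 3 `COc1ccc(CNc2nc(SC)nc3ccccc23)cc1` differs from compound 2 by a group of 2 heavy atoms (1 carbon, 1 oxygen; no ring) in place of a group of 2 heavy atoms (1 carbon, 1 selenium; no ring), on an aromatic carbon. With both measured compounds at the limit, no shift beyond the scatter is expected. Compound 3 is estimated at 100000 nM, range 30000 nM to 300000 nM, an expected step of a number no higher from compound 2 to compound 3 (the limit leaves the size open), most likely reported again as a limit rather than a number.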

Compound 3, concentration for total growth inhibition: > 100000 nM
Compound 3: no number, only a limit (the forecaster's own chance of this, stated with the estimate: 75%); the middle value lies on the limit itself.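

No step can be read from compound 1 or compound 2 to compound 3, as all three give only a limit: the limit of > 100000 nM in this assay, at which 3 of the 3 values shown sit.

The compounds shown leave open whether exchanging the selenium group for methoxy on the aromatic ring alters growth inhibition at all.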